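Acetoxy in place of (4-nitrophenyl)carbonyloxy: an estimate

This account rests on a few compounds, and the source may have more. Where it says the series, first, only, none or still open, it means among the compounds named here.

Three compounds have been measured in a functional assay on cells (Colon cell line, Homo sapiens) for inhibition; a lower number here means a stronger inhibitor, a higher number a weaker inhibitor:
- compound 1, `COC(=O)/C(=C/Cn1c(-c2ccccc2)ncc(NC(=O)OCc2ccccc2)c1=O)COC(=O)c1ccccc1`, gives 13.5 ug/mL
- compound 2, `COC(=O)/C(=C/Cn1c(-c2ccccc2)ncc(NC(=O)OCc2ccccc2)c1=O)COC(=O)c1ccc([N+](=O)[O-])cc1`, gives 7.6 ug/mL
- compound 3, `COC(=O)/C(=C/[C@H](C)NC(=O)Cn1c(-c2ccccc2)ncc(NC(=O)OCc2ccccc2)c1=O)COC(C)=O`, gives 1.6 ug/mL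

Among these three numbers compound 2 holds the second highest. Compound 1 lies closest to it, and compound 3 is furthest away with a lower number, a gap beyond the scatter. Compounds 1 and 2 share everything but one group, and that step, a 1.8-fold lower number from compound 1 to compound 2 (0.25 log units; within the scatter), is too small to count as a real change.

Compound 4, `COC(=O)/C(=C/Cn1c(-c2ccccc2)ncc(NC(=O)OCc2ccccc2)c1=O)COC(C)=O`, is not yet measured. It differs from compound 2 in one place: methyl in place of 4-nitrophenyl on a carbonyl carbon. Compound 4 thus carries the acetoxy group that compound 3 also has, but compound 3 differs from compound 2 in more than one place. Compound 3 gives 1.6 ug/mL in this assay, yet that number cannot be tied to the acetoxy group alone. Among the compounds with values here, the only measured step touching the same region is a 1.8-fold lower number from compound 1 to compound 2 (0.25 log units; within the scatter), which concerns the nitro group only and stayed within the scatter. Within the data shown here, no measured step isolates the exchange of the aromatic ring for methyl. The expected step of a 1.3-fold higher number from compound 2 to compound 4 (0.12 log units; within the scatter) is therefore small, with no direction beyond the scatter. Compound 4 is estimated at 10 ug/mL, within a range from 4 ug/mL to 25 ug/mL.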

Compound 4, half-maximal inhibitory concentration: > 50 ug/mL
Compound 4 ended at the assay's limit; the forecaster's own chance of this, stated with the estimate: 5%; middle value at least 5.0-fold (0.69 log units) away from the limit.
By their numbers in this assay, from the lowest: compound 3; then compounds 2 and 1 (each within the scatter of the next). At a limit, above all of these: compound 4.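

In this assay, the exchange on this carbonyl carbon shows that the aromatic ring matters, which the nitro step alone could not show, as that step stayed within the scatter. Methyl in place of 4-nitrophenyl gives an at least 6.5-fold higher number from compound 2 to compound 4 (0.81 log units; beyond the scatter), and methyl in place of phenyl gives an at least 3.7-fold higher number from compound 1 to compound 4 (0.56 log units; beyond the scatter), so both rings, with or without the nitro group, stand apart from methyl, and the loss does not depend on the nitro group. Compound 4 gives > 50 ug/mL, which is a limit of the assay and not a number: the limit of > 50 ug/mL in this assay, at which 1 of the 4 values shown sits.

The compounds shown leave open what this carbonyl carbon needs, as nothing here lies between methyl, with its single carbon, and the full phenyl or 4-nitrophenyl group. A longer chain such as hexyl, a cyclohexyl ring with no aromatic carbons, or a phenyl ring carrying an amine or a carboxylic acid in place of the nitro group would show whether an aromatic ring is required, or whether a larger group of another kind would serve as well.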